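The source may hold more compounds than are shown below. What is called first, only, known or untested is meant among the compounds shown, and "the series" means these compounds.

Within the data shown here, in an assay on CHO cells for displacement of a labelled ligand from adenosine receptor A3 (Homo sapiens), read by scintillation counting, tested at 10 uM (a higher number here means more inhibition at the concentration tested (going by the name of the read-out), a lower number less inhibition), compound 2 `CC(C)(C)Cc1c(-c2ccc(Cl)c(Cl)c2)sc(N)c1C(=O)c1ccc(Cl)cc1` gives 1%, level with compound 1 `CC(C)(C)Cc1c(-c2ccc(Cl)cc2)sc(N)c1C(=O)c1ccc(Cl)cc1`, which gives 1%; together they are the lowest of the three numbers known so far, and compound 3 `CC(C)(C)Cc1c(-c2ccccc2)sc(N)c1C(=O)c1cccc(Cl)c1` at 5% lies within the scatter of both. The step to compound 4 `CC(C)(C)Cc1c(-c2cccs2)sc(N)c1C(=O)c1ccc(Cl)cc1` is thiophen-2-yl in place of 3,4-dichlorophenyl on an aromatic carbon. Among the measured compounds shown here, no measured step exchanges one aromatic ring for another; the only measured step, no change at the digits printed from compound 1 to compound 2 (within the scatter), adds a chloro group and leaves the number unchanged. All three measured compounds sit near the bottom of the scale, so the expected step of a number 2 percentage points higher from compound 2 to compound 4 (within the scatter) is none beyond the scatter. Compound 4 is estimated to give 3% in this assay, within a range from -8% to 15%.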

Compound 4, a percentage reported as inhibition, at one concentration (the size of the read-out at that concentration, not a potency): 1%
For compound 4 the middle estimate is 2 percentage points above the measured one; measured number inside the range.
By their numbers in this assay, from the lowest: compounds 1, 2, 4 and 3 (each within the scatter of the next).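

In this assay, exchanging the aromatic ring on the carbon next to the ring sulfur gives no change at the digits printed from compound 2 to compound 4 (within the scatter) and no change at the digits printed from compound 1 to compound 4 (within the scatter), so thiophen-2-yl reads the same as either chlorinated phenyl group. Among these compounds, until now, the only readable step at this position had added a chloro group; this is the first readable change of the ring itself, though all these numbers sit near the bottom of the scale. No measured evidence accounts for this flat result. Going by these compounds, whether an amine or a carboxylic acid at this position would lift the number beyond the scatter stays open.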